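The compounds below may be only part of what the source reports. "The series", "measured", "known", "first", "only" and "open" are said of these compounds alone.

Measured so far:
compound 1, `Cc1cccc(C(=O)N2CCCC(C(=O)Nc3ccc(Cl)cc3)C2)c1`: 0%
compound 2, `O=C(c1ccccc1)c1cccc(C(=O)N2CCCC(C(=O)Nc3ccc(Cl)cc3)C2)c1`: 0%

In an ADME assay on PC-3 cells (Homo sapiens) for cytotoxicity, read by WST assay, tested at 100 uM (a higher number here means more inhibition at the concentration tested (going by the name of the read-out), a lower number less inhibition), compound 2 gives 0%, and on these numbers it stands level with compound 1 within the scatter. For the measured compounds named here, the only measured step, no change at the digits printed from compound 1 to compound 2 (within the scatter), was benzoyl in place of methyl on an aromatic carbon, and it left the read-out flat.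

Compound 3, `COCc1cccc(C(=O)N2CCCC(C(=O)Nc3ccc(Cl)cc3)C2)c1`, differs from compound 2 by methoxymethyl in place of benzoyl on an aromatic carbon. This step bears on that one measured step in that it again exchanges the group on the same aromatic carbon, and that exchange produced no change beyond the scatter. With both measured compounds showing no inhibition at this concentration, compound 3 is expected to show a step of no change at the digits printed from compound 2 to compound 3 (within the scatter), none beyond the scatter. Compound 3 is therefore estimated at 0%, with a range from 0% to 12%.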

Compound 3, a percentage reported as inhibition, at one concentration (the size of the read-out at that concentration, not a potency): 0%
For compound 3 middle estimate and measured number coincide at the digits printed; low and high end bracket the measured number.
By their numbers in this assay, from the lowest: compounds 1, 2 and 3 (each within the scatter of the next).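

In this assay, methoxymethyl in place of benzoyl on the aromatic carbon left the read-out flat (no change at the digits printed from compound 2 to compound 3 (within the scatter)), even though a ring-free group of fewer heavy atoms replaced one carrying a six-membered aromatic ring. Set against the methyl of compound 1, methoxy in place of hydrogen on the saturated chain carbon bound to the aromatic carbon also moved nothing (no change at the digits printed from compound 1 to compound 3 (within the scatter)), so methyl, benzoyl and methoxymethyl all lie within the scatter of one another at this position. No measurement here offers an explanation for this flat result.

The compounds shown leave open whether an amine or a carboxylic acid on this aromatic carbon would produce any inhibition. They also leave open whether a change elsewhere on the shared core would do so.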